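A few compounds are considered here, and "the series" means these few. Any claim that something is new, unique, unknown or untested is made for them only; others in the source may bear on it.

Values measured in an ADME assay on L929 cells (Mus musculus, culture collection number NCTC 929) for cytotoxicity, read by MTT assay, with a stated time of 72 h (on this read-out lower numbers stand for stronger inhibition and higher numbers for weaker inhibition), are these:
Compound 1 `Cc1cc(O)c(C(=O)NCCCc2ccccc2)c(=O)o1` gives 143000 nM
Compound 2 `Cc1cc(O)c(C(=O)Nc2ccccc2)c(=O)o1` gives > 200000 nM
Compound 3 `CCCCCCNC(=O)c1c(O)cc(C)oc1=O` gives 196000 nM

Compound 2 shows > 200000 nM, which is a limit of the assay and not a number. Among the compounds with values here, compound 4 `Cc1cc(O)c(C(=O)Nc2ccc(OCc3ccccc3)cc2)c(=O)o1` carries benzyloxy in place of hydrogen on an aromatic carbon, para to a large group, and this is its one change from compound 2 (benzyloxy in place of hydrogen on an aromatic carbon).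

Within the data shown here, no measured step makes this same change, so the guidance is indirect. Two steps exchange one group for another on the amide side of the shared core: a 1.4-fold higher number from compound 1 to compound 3 (0.14 log units; within the scatter) and an at least 1.0-fold lower number from compound 2 to compound 3 (0.00 log units; that floor lies within the scatter). Neither shows a change beyond the scatter. On that basis, no step beyond the scatter is expected, although the limit on compound 2 leaves the true starting point unknown. The estimated step is an at least 1.2-fold lower number from compound 2 to compound 4 (0.09 log units; that floor lies within the scatter) in this assay, and a larger one remains possible. For compound 4 the estimate is 160000 nM, with an expected range from 60000 nM to 300000 nM.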

Compound 4, half-maximal inhibitory concentration: > 200000 nM
Compound 4: a limit, no number; the forecaster's own chance of this, stated with the estimate: 35%; middle value at least 1.2-fold (0.09 log units) from the limit.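

In this assay compound 4 gives > 200000 nM, which is a limit of the assay and not a number. Within the data shown here, compound 2 also sits at a limit, so no step between compound 2 and compound 4 can be read: the limit of > 200000 nM in this assay, at which 2 of the 4 values shown sit. On these data alone, what benzyloxy in place of hydrogen on an aromatic carbon does to the value in this assay stays open.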